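The source may report more compounds than this note shows. Statements on the series, on what has been measured and on what is new or still open speak of the compounds shown alone.

Measured compounds:
compound 1, `COc1cc2ncnc(Nc3cccc(Cl)c3F)c2cc1OCCCCC(=O)Nc1ccc(S(N)(=O)=O)cc1`, 6930 nM
compound 2, `COc1cc2ncnc(Nc3ccc(C(F)(F)F)cc3)c2cc1OCCCCC(=O)Nc1ccc(S(N)(=O)=O)cc1`, 12000 nM
compound 3, `NS(=O)(=O)c1ccc(NC(=S)Nc2ccc3ncnc(Nc4ccc(C(F)(F)F)cc4)c3c2)cc1`, 17100 nM

All three were tested in a functional assay on NCI-H1975 cells (Homo sapiens) for antiproliferative activity, read by MTT assay, with a stated time of 72 h; on this read-out lower numbers stand for stronger inhibition and higher numbers for weaker inhibition. Compound 1 and compound 2 share one core; compound 3 has another, and the difference between the two cores is not broken down here. Compound 1 and compound 2 differ only in 3-chloro-2-fluorophenyl in place of 4-(trifluoromethyl)phenyl on a nitrogen on an aromatic ring, and that change gave a 1.7-fold lower number from compound 2 to compound 1 (0.24 log units; within the scatter). Compound 4, `NS(=O)(=O)c1ccc(NC(=S)Nc2ccc3ncnc(Nc4cccc(Cl)c4F)c3c2)cc1`, has not yet been measured; it stands to compound 3 as compound 1 stands to compound 2, the same change, (3-chloro-2-fluorophenyl in place of 4-(trifluoromethyl)phenyl on a nitrogen on an aromatic ring), in the same place on the core of compound 3.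

For the measured compounds named here, since the only measured instance of this change stayed within the scatter, compound 4 is expected to give a 1.6-fold lower number from compound 3 to compound 4 (0.19 log units; within the scatter), a step of about the same size as the earlier one. The estimate for compound 4 is 11000 nM, with a range from 5000 nM to 25000 nM, resting on the value of compound 3 and on the step seen between compound 2 and compound 1.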

Compound 4, half-maximal inhibitory concentration: 25100 nM
Beside the measured number, compound 4's estimate is 2.3-fold (0.36 log units) below it, and the stated range ends below it.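

In this assay, putting 3-chloro-2-fluorophenyl in place of 4-(trifluoromethyl)phenyl on the second core gave a 1.5-fold higher number from compound 3 to compound 4 (0.17 log units; within the scatter), which stays within the scatter, as the same change did on the first core. Set side by side, the two steps do not differ: the same change on two cores in this assay, a 1.7-fold lower number (0.24 log units; within the scatter) from compound 2 to compound 1 and a 1.5-fold higher number (0.17 log units; within the scatter) from compound 3 to compound 4, 2.5-fold (0.41 log units) apart, within the scatter of two such steps. The change thus left the read-out within the scatter on both cores, but two such small steps cannot show whether it has any real effect or whether that effect depends on the core.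

The compounds shown leave open whether a phenyl group carrying an amine or a carboxylic acid, on the same nitrogen, would move the number beyond the scatter on either core.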